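Swapping Trifluoromethyl for Methoxy on the Pyridine-Bearing Chain

The compounds below may be only part of what the source reports. "The series", "measured", "known", "first", "only" and "open" are said of these compounds alone.

The compounds measured so far, all sharing one core, are:
compound 1, `O=C(/C=C/c1ccccc1)N1CCc2c(Cl)c(O)c(O)c(Cl)c2C1`, giving 41%;
compound 2, `O=C(CCCc1ccc([N+](=O)[O-])cn1)N1CCc2c(Cl)c(O)c(O)c(Cl)c2C1`, giving 33%;
compound 3, `O=C(CCCc1ccc(C(F)(F)F)cn1)N1CCc2c(Cl)c(O)c(O)c(Cl)c2C1`, giving 19%.

These numbers come from a functional assay (Homo sapiens), tested at 10 uM; on this read-out lower numbers stand for a stronger effect and higher numbers for a weaker effect at the one concentration tested. On this scale compound 3 stands lowest of the three, and so shows the strongest effect: its nearest neighbour is compound 2, and the furthest is compound 1, both beyond the scatter.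

Compound 4, `COc1ccc(CCCC(=O)N2CCc3c(Cl)c(O)c(O)c(Cl)c3C2)nc1`, has not yet been measured. It differs from compound 3 in one place: methoxy in place of trifluoromethyl on an aromatic carbon. A methoxy thus takes the place of the trifluoromethyl on the aromatic carbon of the six-membered ring with one nitrogen.

Among the compounds with values here, only one measured step touches this position, a number 14 percentage points lower from compound 2 to compound 3 (beyond the scatter), which shows that the group at this carbon can move the read-out by a modest amount. Within the data shown here, no measured pair compares methoxy with trifluoromethyl, so the direction is open. The expected change is therefore a modest one, most likely a rise back toward the level of compound 2, given as a number 11 percentage points higher from compound 3 to compound 4 (beyond the scatter). Compound 4 is estimated at 30%, within a range from 15% to 48%.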

Compound 4, a percentage reported as activity, at one concentration (the size of the read-out at that concentration, not a potency): 31%
Compound 4: the middle estimate sits 1 percentage points below what was measured; measured number inside the range.
By their numbers in this assay, from the lowest: compound 3; then compounds 4, 2 and 1 (each within the scatter of the next).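

In this assay, the change from trifluoromethyl to methoxy at this carbon gives a number 12 percentage points higher from compound 3 to compound 4 (beyond the scatter) and so supplies a second measured step at this position, one that starts from trifluoromethyl and leads to a different group. Methoxy in place of nitro gives a number 2 percentage points lower from compound 2 to compound 4 (within the scatter), so these two groups cannot be told apart on this read-out, and among the three groups compared at this carbon, only trifluoromethyl stands apart from the others, with no compound here going against that. The data include no measurement that could explain why trifluoromethyl stands apart, so the result describes what happens at this position but not the reason for it.

The compounds shown leave open how other groups at this same carbon would read, such as an amine, a carboxylic acid, a chlorine or a plain hydrogen, and so whether trifluoromethyl is unusual or simply one of several groups that give a low number. They also leave open whether the low number of compound 3 would survive with a shorter or longer chain linking the ring to the carbonyl.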